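This account rests on a few compounds, and the source may have more. Where it says the series, first, only, none or still open, it means among the compounds named here.

Measured compounds:
- compound 1 `CCc1nc(Cl)c2n1CCN([C@@H](C(=O)NC)c1ccccc1)[C@H]2COc1cccc(C(F)(F)F)c1`: 312 nM
- compound 2 `CCc1nc(Cl)c2n1CCN([C@@H](C(=O)NC)c1ccccc1)[C@H]2CCc1ccc(C(F)(F)F)c(F)c1F`: 17 nM

In a functional assay on CHO cells for antagonist activity at Orexin/Hypocretin receptor type 1 (Homo sapiens), read by FLIPR and calcium flux (a lower number here means a stronger inhibitor, a higher number a weaker inhibitor), compound 1 gives 312 nM, the highest of the two numbers recorded so far. Compound 2 gives 17 nM in this assay, a markedly lower number; the gap between the two compounds is well beyond the scatter of the method. Among the measured compounds shown here, compound 2 and compound 1 differ in more than one place, so no single-site step connects them.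

Compound 3 `CCc1nc(Cl)c2n1CCN([C@@H](C(=O)NC)c1ccccc1)[C@H]2CCc1ccc(F)c(F)c1F` is not yet measured. Relative to compound 1 the change is 2,3,4-trifluorobenzyl in place of 3-(trifluoromethyl)phenoxy on a saturated chain carbon bound to a saturated ring carbon. The benzyl-linked aryl group of compound 3 resembles that of compound 2, which carries a trifluoromethyl group in place of one of the fluorines of compound 3.

For this assay, the step of a 7.8-fold lower number from compound 1 to compound 3 (0.89 log units; beyond the scatter) is expected to run downward, toward a stronger inhibitor, and to be beyond the scatter, because compound 2 with its related benzyl linkage gives 17 nM. Compound 3 is expected to fall somewhat short of compound 2. Compound 3 is estimated at 40 nM, with a plausible range from 12 nM to 130 nM.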

Compound 3, half-maximal inhibitory concentration: 30 nM
Beside the measured number, compound 3's estimate is 1.3-fold (0.12 log units) above it, within the range that was stated.
By their numbers in this assay, from the lowest: compounds 2 and 3 (each within the scatter of the next); then compound 1.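

Working notes on the series: in this assay, the exchange on a saturated chain carbon bound to a saturated ring carbon can now be read as a change in one place, since 2,3,4-trifluorobenzyl in place of 3-(trifluoromethyl)phenoxy gives a 10-fold lower number from compound 1 to compound 3 (1.02 log units; beyond the scatter) and so is a large step. On an aromatic carbon of the benzyl-linked ring, fluoro in place of trifluoromethyl gives a 1.8-fold higher number from compound 2 to compound 3 (0.25 log units; within the scatter), so this assay does not separate these two groups at that place, and the series tolerates either there within the compounds shown. Nothing at hand accounts for the size of the step from the phenoxy to the benzyl group.

The step from compound 1 swaps the oxygen-linked aryl group and the ring substitution together, so the compounds shown cannot assign it to either part; a 2,3,4-trifluorophenoxy group on the same carbon would separate the two. Also open, from the compounds shown here alone, is how far the aromatic carbon tolerates other groups, such as a nitrile or a methoxy group, in place of fluoro and trifluoromethyl.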